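This account rests on a few compounds, and the source may have more. Where it says the series, first, only, none or still open, it means among the compounds named here.

In a functional assay on B16 cells (Mus musculus) for cytotoxicity, read by MTT assay, with a stated time of 48 h (on this read-out higher numbers stand for weaker inhibition and lower numbers for stronger inhibition), compound 2 `COc1cccc(Cn2cc(-c3ccc4ccccc4c3)nn2)c1` gives only a limit of the assay, > 100000 nM. Compound 1 `COc1ccc(-c2cn(C[C@H]3COC(C)(C)O3)nn2)cc1` likewise gives only a limit in this assay, > 100000 nM. Going by the values given here, no step between measured compounds can be counted, since both values sit at the same limit. Compound 3 `CC1(C)OCC(Cn2cc(-c3ccc4ccccc4c3)nn2)O1` is not yet measured; it carries 2,2-dimethyl-1,3-dioxolan-4-yl in place of 3-methoxyphenyl on a saturated chain carbon bound to an aromatic nitrogen, the group that compound 1 already bears. Because both measured values sit at the limit (the limit of > 100000 nM in this assay, at which 2 of the 2 values shown sit), the expected step is a step that the limit leaves unreadable from compound 2 to compound 3, none beyond the scatter. Compound 3 is expected at 200000 nM, between 80000 nM and 1000000 nM, most likely again reported only as a limit.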

Compound 3, half-maximal inhibitory concentration: 6600 nM
Beside the measured number, compound 3's estimate is 30-fold (1.48 log units) above it, outside the stated range (below it).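

In this assay, the swap on a saturated chain carbon bound to an aromatic nitrogen gives the first readable value, and 2,2-dimethyl-1,3-dioxolan-4-yl in place of 3-methoxyphenyl brings an at least 15-fold lower number from compound 2 to compound 3 (1.18 log units; beyond the scatter), which here means stronger inhibition. This position therefore does influence the read-out. Compound 1 bears the same group and gives > 100000 nM, a limit of the assay, so the group alone does not guarantee a readable value.

As far as these compounds go, what an open-chain diol or an amine would give at this place remains open.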